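Chloro at the chain end of a trimethoxyphenyl amide

This account rests on a few compounds, and the source may have more. Where it says the series, first, only, none or still open, it means among the compounds named here.

Three compounds share a core carrying three methoxy groups, each bearing a benzyl group on the nitrogen. Compound 1 `CCCCC(=O)N(Cc1ccc(OC)c(O)c1)c1cc(OC)c(OC)c(OC)c1` is an amide with a pentanoyl chain; compound 3 `C/C=C/C(=O)N(Cc1ccc(OC)cc1)c1cc(OC)c(OC)c(OC)c1` is an amide with a butenoyl chain; compound 2 `COc1ccc(CNc2cc(OC)c(OC)c(OC)c2)cc1C` has no carbonyl at all and is a simple secondary amine. In a functional assay on KYSE-450 cells (Homo sapiens) for inhibition, read by MTT assay, with a stated time of 48 h (on this read-out lower numbers stand for stronger inhibition and higher numbers for weaker inhibition), compound 1 gives 300 nM. In this assay, among the measured compounds shown here, compound 3 gives 420 nM, a number that sits within the usual scatter of the one for compound 1, so the two cannot be told apart. Compound 2, by contrast, gives 73800 nM in this assay, a gap from compound 1 far beyond the scatter; the two amides thus occupy the low end and the amine stands far away.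

Compound 4 `COc1ccc(CN(C(=O)CCCCCl)c2cc(OC)c(OC)c(OC)c2)cc1O` differs from compound 1 in one place: chloro in place of hydrogen on a saturated chain carbon, four bonds along the chain from a carbonyl carbon. The chloro enters on a saturated chain carbon, four bonds along the chain from a carbonyl carbon, so the amide and the rest of the core are untouched. For the measured compounds named here, with no measured pair showing such a change, the step from compound 1 to compound 4 is expected to be small, no change at the digits printed from compound 1 to compound 4 (within the scatter), in no clear direction and not beyond the scatter. Compound 4 is therefore estimated at 300 nM in this assay, with a range from 120 nM to 800 nM.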

Compound 4, half-maximal inhibitory concentration: 770 nM
The estimate for compound 4 lay 2.6-fold (0.41 log units) below the measured number; low and high end bracket the measured number.
By their numbers in this assay, from the lowest: compounds 1, 3 and 4 (each within the scatter of the next, the first and the last beyond it); then compound 2.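

In this assay, among the compounds shown here, the chloro gives a 2.6-fold higher number from compound 1 to compound 4 (0.41 log units; beyond the scatter) and so makes a difference that can be read, which the earlier compounds, with no pair differing in one place, could not show. This saturated chain carbon, four bonds along the chain from a carbonyl carbon, is therefore not indifferent to what it carries, although a single heavy atom in place of hydrogen moves the number only modestly and the amide and the rest of the core stay as they were. Nothing measured on these compounds says why the number rises at this position.

Whether the step belongs to the chloro itself stays open, since the compounds shown do not tell how a fluoro, a hydroxyl, an amine or a carboxylic acid at the same chain end would compare, or whether a longer chain ending in chloro would follow the same course. For the compounds shown here, this is also the only step of its kind here, so it remains unknown whether the same change on the butenoyl chain of compound 3 would give a step of similar size.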